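A few compounds are considered here, and "the series" means these few. Any claim that something is new, unique, unknown or untested is made for them only; others in the source may bear on it.

Measured so far, each a single cytotoxicity read-out on cells:
compound 1 `O=C1CSC(c2cccc(Cl)c2)N1CCN1CCCCC1`: 100%
compound 2 `Cc1ccc(C2SCC(=O)N2CCN2CCCCC2)cc1`: 100%
compound 3 `O=C1CSC(c2cccc(F)c2)N1CCN1CCCCC1`: 100%

All three values come from an ADME assay on Vero cells (Chlorocebus sabaeus) for cytotoxicity, read by neutral red uptake, tested at 25 ug/mL (a lower number here means a stronger effect, a higher number a weaker effect of the compound at the concentration tested), where the compounds were read at one concentration. Compound 3 stands level with compound 1 and compound 2 at the digits shown. The step of no change at the digits printed from compound 1 to compound 3 (within the scatter) lies within the scatter, and so does the step of no change at the digits printed from compound 2 to compound 3 (within the scatter); the three compounds cannot be told apart by this read-out.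

Compound 4 `O=C1CSC(c2ccccc2Cl)N1CCN1CCCCC1` has not yet been measured. It differs from compound 3 in one place: 2-chlorophenyl in place of 3-fluorophenyl on a saturated ring carbon. For the measured compounds named here, three measured steps bear on this change, each of them also exchanging the aromatic group on a saturated ring carbon of the shared core or its halogen: no change at the digits printed from compound 1 to compound 2 (within the scatter), no change at the digits printed from compound 1 to compound 3 (within the scatter) and no change at the digits printed from compound 2 to compound 3 (within the scatter). Going by the values given here, none of them moved the read-out beyond the scatter, and there is no measured step that points the other way. The expectation for compound 4 is therefore a step of no change at the digits printed from compound 3 to compound 4 (within the scatter), that is, no movement beyond the scatter in this assay. Compound 4 is thus estimated at 100%, with a range from 85% to 100%.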

Compound 4, a percentage reported as activity, at one concentration (the size of the read-out at that concentration, not a potency): 100%
For compound 4 middle estimate and measured number coincide at the digits printed; the measured number falls inside the stated range.
By their numbers in this assay, from the lowest: compounds 1, 2, 3 and 4 (each within the scatter of the next).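

The 2-chlorophenyl group brings a new arrangement to this saturated ring carbon: earlier exchanges changed the substituent on the aromatic ring, whereas going from 3-chlorophenyl to 2-chlorophenyl keeps the chlorine and changes only its place on that ring, and in this assay this gives no change at the digits printed from compound 1 to compound 4 (within the scatter) for that isolated shift. The comparisons that alter the halogen or replace the methyl group as well read the same way, with no change at the digits printed from compound 3 to compound 4 (within the scatter) when 2-chlorophenyl replaces 3-fluorophenyl and no change at the digits printed from compound 2 to compound 4 (within the scatter) when it replaces 4-methylphenyl. So across these four compounds, this read-out at its single concentration does not respond to where the chlorine sits on the aromatic ring, and no other measurement is available to account for that.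

The compounds shown leave open whether a more different substituent on the aromatic ring, such as an amine or a carboxylic acid, would separate itself from these four in this assay and give a lower number. Going by these compounds, it also remains open whether replacing the phenyl group at this carbon with a non-aromatic group, such as a longer alkyl chain, would change the picture.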